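The source may hold more compounds than are shown below. What is called first, only, known or untested is meant among the compounds shown, and "the series" means these compounds.

Compounds measured so far:
compound 1, `O=C(NO)c1ccc(NCc2nc(-c3ccc(Br)o3)nn2-c2ccccc2)cc1`, with 55.8% in an assay on Sf9 cells for inhibition of protein deacetylase HDAC6 (Homo sapiens), read by fluorescence, with a stated time of 40 min, tested at 100 nM; a higher number here means more inhibition at the concentration tested (going by the name of the read-out), a lower number less inhibition
compound 2, `O=C(O)c1ccc(NCc2nc(-c3ccccc3)nn2-c2ccccc2)cc1`, with -0.4% in this assay

Of the two numbers, compound 1 stands highest, and compound 2, which differs from it in more than one place, lies far below it, beyond the usual scatter. For the measured compounds named here, no single-change step between measured compounds is available, so the two values only show that compound 1 carries clear inhibition where compound 2 shows none.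

Compound 3, `O=C(NO)c1ccc(NCc2nc(-c3ccccn3)nn2-c2ccccc2)cc1`, has not yet been tested in this assay. It keeps the hydroxamic acid of compound 1, and differs from it in one place: pyridin-2-yl in place of 5-bromofuran-2-yl on an aromatic carbon. Going by the values given here, with no measured step of this kind to lean on, a step from compound 1 to compound 3 of modest size downward, at the edge of the scatter, is expected, a number 10.8 percentage points lower from compound 1 to compound 3 (beyond the scatter). For compound 3 in this assay the estimated value is 45%, with a range from 20% to 70%.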

Compound 3, a percentage reported as inhibition, at one concentration (the size of the read-out at that concentration, not a potency): 58.6%
Estimate against measurement, compound 3: 13.6 percentage points below, within the range that was stated.
By their numbers in this assay, from the lowest: compound 2; then compounds 1 and 3 (each within the scatter of the next).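

Putting pyridin-2-yl in place of 5-bromofuran-2-yl, on the aromatic carbon of the five-membered ring with three nitrogens, gives a number 2.8 percentage points higher from compound 1 to compound 3 (within the scatter) in this assay. The inhibition seen with the hydroxamic acid at this concentration is therefore not tied to the bromine or to a five-membered ring at this position, as a six-membered aromatic ring serves within the scatter. Nothing measured on either group accounts for this match.

The compounds shown give no single-change pair of hydroxamic acid against carboxylic acid, since compound 2 differs from compound 1 in more than one place. On these data alone, it also remains open how an amine or a simple alkyl chain, in place of an aromatic ring at this position, would read in this assay.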